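The compounds below may be only part of what the source reports. "The series", "measured", "known", "first", "only" and "open" are said of these compounds alone.

Going by the values given here, compound 2, whose structure is `Brc1ccc(-c2cn3ccnc3c(-c3ccc4ncn(C5CCCCC5)c4c3)n2)cc1`, stands at the top of the two numbers so far in a functional assay on OVCAR-3 cells (Homo sapiens) for inhibition, read by sulforhodamine B assay, with a stated time of 48 h, tested at 10 uM (a higher number here means more inhibition at the concentration tested (going by the name of the read-out), a lower number less inhibition), where compound 2 gives 26.3%. Its nearest neighbour is compound 1, `Fc1ccc(-c2cn3ccnc3c(-c3ccc4ncn(C5CCCCC5)c4c3)n2)cc1`, which in this assay gives 7.88%. Among the compounds with values here, the one step that connects them, a number 18.4 percentage points higher from compound 1 to compound 2 (beyond the scatter), is the only measured step available.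

Compound 3, `COc1ccccc1-c1cn2ccnc2c(-c2ccc3ncn(C4CCCCC4)c3c2)n1`, is the next compound to be measured. It differs from compound 2 at a single place: 2-methoxyphenyl in place of 4-bromophenyl on an aromatic carbon. The measured step from compound 1 to compound 2 changed only a halogen at the same position on the same six-membered aromatic ring of carbon only; the change to compound 3 replaces that ring substituent altogether with a 2-methoxyphenyl group, so that step bears on it only loosely and gives no direction that can be trusted. Within the data shown here, with the one available step pointing upward for a heavier halogen and nothing at all about a methoxy group, the estimated step in this assay is a number 11.3 percentage points lower from compound 2 to compound 3 (beyond the scatter), downward but of uncertain size.

Compound 3 is therefore expected to give about 15% in this assay, with a likely range from 0% to 40%.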

Compound 3, a percentage reported as inhibition, at one concentration (the size of the read-out at that concentration, not a potency): 6.57%
Compound 3: middle estimate off by 8.4 percentage points, on the high side; low and high end bracket the measured number.
By their numbers in this assay, from the lowest: compounds 3 and 1 (each within the scatter of the next); then compound 2.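

Putting 2-methoxyphenyl in place of 4-bromophenyl on this aromatic carbon, next to the ring nitrogen, gives in this assay a number 19.7 percentage points lower from compound 2 to compound 3 (beyond the scatter). Replacing 4-fluorophenyl with the same group gives a number 1.3 percentage points lower from compound 1 to compound 3 (within the scatter), so 2-methoxyphenyl and 4-fluorophenyl cannot be told apart at this position in this assay. Among the three groups shown here, the higher number therefore belongs to 4-bromophenyl alone, and an oxygen-bearing substituent on the phenyl ring does not match it, while the step to the fluoro compound shows no separation at all. Nothing measured here bears on why the numbers fall this way.

The compounds shown leave open how much of the step away from 4-bromophenyl comes from the change of substituent and how much from where it stands on the phenyl ring, as 2-methoxyphenyl differs from 4-bromophenyl in both at once. They also leave open how a chloro group, an amine or a carboxylic acid on that phenyl ring would read in this assay.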